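This account rests on a few compounds, and the source may have more. Where it says the series, first, only, none or still open, it means among the compounds named here.

Measured so far:
- compound 1, `C[C@H]1[C@H](NCc2ccc(C(C)(C)C)s2)C[C@H]2C[C@@H]1C2(C)C`: 780 nM
- compound 2, `C[C@H]1[C@H](NCc2ccsc2)C[C@H]2C[C@@H]1C2(C)C`: 50000 nM

In an ADME assay on MDCK cells (Canis lupus familiaris) for cytotoxicity, read by microscopy, with a stated time of 48 h (on this read-out higher numbers stand for lower toxicity in this test and lower numbers for higher toxicity in this test), compound 1 gives the lowest of the two numbers, so it is the more toxic of the two in this test; compound 2 gives a value that is far higher, a gap well beyond the scatter. Compound 3, `C[C@H]1[C@H](NCc2ccc(-c3ccc(Br)s3)s2)C[C@H]2C[C@@H]1C2(C)C`, has not been measured. It differs from compound 1 in one place: 5-bromothiophen-2-yl in place of tert-butyl on an aromatic carbon. The new group sits on an aromatic carbon of a five-membered aromatic ring with one sulfur, next to the ring sulfur. For the measured compounds named here, with no measured step of this kind to lean on, the expectation is a step of modest size in this assay, if any, and not clearly in one direction. Compound 3 is therefore expected to land near 1000 nM, between 250 nM and 5000 nM, which means an expected 1.3-fold higher number from compound 1 to compound 3 (0.11 log units; within the scatter).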

Compound 3, minimum cytotoxic concentration: 780 nM
Compound 3: the middle estimate sits 1.3-fold (0.11 log units) above what was measured, within the range that was stated.
By their numbers in this assay, from the lowest: compounds 1 and 3 (each within the scatter of the next); then compound 2.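

Replacing tert-butyl with 5-bromothiophen-2-yl on an aromatic carbon, next to the ring sulfur, gives no change at the digits printed from compound 1 to compound 3 (within the scatter) in this assay. This position can therefore carry a group with a second five-membered aromatic ring and a bromine in place of a group with no ring, and this read-out does not tell the two groups apart. There is no outside evidence to explain this result.

The compounds shown leave open what an amine or a carboxylic acid on this same carbon would give in this assay. They also leave open whether the bromine matters, since the same five-membered ring without its bromine does not appear among them.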